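The source may hold more compounds than are shown below. What is called first, only, known or untested is meant among the compounds shown, and "the series" means these compounds.

Measured compounds:
- compound 1, `O=c1[nH]nc2n(c1=O)CCN2c1ccccc1`: 0%
- compound 2, `N=c1c(=O)[nH]nc2n1CCN2c1ccccc1Cl`: 6%

Of the compounds shown here, two have been tested in a functional assay on A549 cells (Homo sapiens) for antiproliferative activity, with a stated time of 72 h, tested at 10 ug/mL; on this read-out lower numbers stand for a weaker effect and higher numbers for a stronger effect at the one concentration tested. Compound 1, `O=c1[nH]nc2n(c1=O)CCN2c1ccccc1`, gives 0% in this assay. Compound 2, `N=c1c(=O)[nH]nc2n1CCN2c1ccccc1Cl`, gives 6% in this assay. On these two numbers compound 2 carries the larger figure, but the gap to compound 1 lies within the usual scatter of repeated measurements, so the two compounds cannot be told apart on this read-out; both show essentially no effect at the single concentration tested.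

Compound 3, `N=c1c(=O)[nH]nc2n1CCN2c1ccccc1`, has not yet been measured. It differs from compound 2 in one place: hydrogen in place of chloro on an aromatic carbon. Within the data shown here, no step between measured compounds is available for this change, so its effect has to be judged from the two measured values alone, both of which sit at the floor of the read-out.

Given that compound 2 gives 6% and compound 1 gives 0%, compound 3 is expected to show no step beyond the scatter in this assay, with an estimated step of a number 3 percentage points lower from compound 2 to compound 3 (within the scatter). Compound 3 is therefore estimated at 3%, within a range from 0% to 15%.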

Compound 3, a percentage reported as inhibition, at one concentration (the size of the read-out at that concentration, not a potency): 7%
Compound 3: the middle estimate sits 4 percentage points below what was measured; low and high end bracket the measured number.
By their numbers in this assay, from the lowest: compounds 1, 2 and 3 (each within the scatter of the next).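

Among these compounds, the first direct reading of this change comes from the pair compound 2 and compound 3: in this assay, hydrogen in place of chloro on an aromatic carbon, ortho to a large group, gives a number 1 percentage points higher from compound 2 to compound 3 (within the scatter). At this position, then, the chloro group makes no difference that this read-out can detect, and compound 2 and compound 3 cannot be told apart, both lying close to the bottom of the scale at the one concentration tested. Nothing measured here offers an explanation for this result.

What the compounds shown leave open is whether any group on this aromatic carbon can move the number clear of the scatter, for example a methoxy group, an amine or a carboxylic acid. Also open, from the compounds shown here alone, is whether chloro and hydrogen would still match in a read-out that gives a potency, since a single concentration at which both compounds show so little effect offers little room to separate them.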